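A few compounds are considered here, and "the series" means these few. Any claim that something is new, unique, unknown or untested is made for them only; others in the source may bear on it.

Compound 3 `Nc1scc(CN2CCN(c3cccc(F)c3)CC2)c1C(=O)c1ccc(Cl)cc1` gives -18% in a functional assay on CHO cells with adenosine receptor A1 (Homo sapiens) as the target, read by cAMP accumulation and immunoassay, with a stated time of 6 min, tested at 0.01 uM; a higher number here means a weaker effect of the compound at the concentration tested, a lower number a stronger effect. Among the three compounds measured it carries the lowest number: against compound 1 `CC(C)N1CCN(Cc2csc(N)c2C(=O)c2ccc(Cl)cc2)CC1`, with -1%, the step of a number 17 percentage points lower from compound 1 to compound 3 (beyond the scatter) is beyond the scatter, whereas against compound 2 `Nc1scc(CN2CCN(c3ccc(Cl)cc3F)CC2)c1C(=O)c1ccc(Cl)cc1`, with -9.2%, the step of a number 8.8 percentage points lower from compound 2 to compound 3 (within the scatter) is within it. Compound 4 `Nc1scc(CN2CCN(CCCc3ccc(Cl)cc3)CC2)c1C(=O)c1ccc(Cl)cc1` differs from compound 3 at the same ring nitrogen where all three measured compounds vary: 3-(4-chlorophenyl)propyl in place of 3-fluorophenyl on an amine nitrogen in a ring. For the measured compounds named here, the steps that bear on this change are those at that nitrogen, a number 8.2 percentage points lower from compound 1 to compound 2 (within the scatter), a number 17 percentage points lower from compound 1 to compound 3 (beyond the scatter) and a number 8.8 percentage points lower from compound 2 to compound 3 (within the scatter); only the move from isopropyl to 3-fluorophenyl passed the scatter, and the others were modest. Since the three readings span a narrow band, the expected step of a number 8 percentage points higher from compound 3 to compound 4 (within the scatter) is small and lies within the scatter. Compound 4 is therefore estimated at -10% in this assay, with a range from -25% to 5%.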

Compound 4, a percentage reported as activity, at one concentration (the size of the read-out at that concentration, not a potency): 0%
Compound 4: the middle estimate sits 10 percentage points below what was measured; low and high end bracket the measured number.
By their numbers in this assay, from the lowest: compounds 3, 2, 1 and 4 (each within the scatter of the next, the first and the last beyond it).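

In this assay, the 3-(4-chlorophenyl)propyl group at this ring nitrogen gives a number 18 percentage points higher from compound 3 to compound 4 (beyond the scatter) and so shows that the number here can also move upward when 3-fluorophenyl is replaced. An aromatic ring on this nitrogen therefore does not by itself go with the lowest number: compound 4 also carries one, set on a propyl chain, yet a number 1 percentage points higher from compound 1 to compound 4 (within the scatter) and a number 9.2 percentage points higher from compound 2 to compound 4 (within the scatter) leave it not separable from either the isopropyl or the 4-chloro-2-fluorophenyl compound. Nothing available explains this step.

The change to compound 4 brings in both the propyl chain and the chlorine, and the compounds shown do not separate the two. Going by these compounds, a plain 3-phenylpropyl group or a benzyl group on this nitrogen remains open, as does a 3-(3-fluorophenyl)propyl group.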